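This account rests on a few compounds, and the source may have more. Where it says the series, first, only, none or still open, it means among the compounds named here.

Measured so far in a functional assay on KM12 cells (Homo sapiens) for inhibition, read by sulforhodamine B assay, with a stated time of 48 h; on this read-out lower numbers stand for stronger inhibition of growth and higher numbers for weaker inhibition of growth:
- compound 1, `COc1ccc(-c2[nH]c3ccccc3c2/C=C(\C#N)S(=O)(=O)c2ccccc2)cc1`: 374 nM
- compound 2, `COc1ccc2[nH]c(-c3ccccc3)c(C=C(C#N)C#N)c2c1`: 3500 nM
- compound 3, `CCOC(=O)C(=Cc1c(-c2ccccc2)[nH]c2ccccc12)C(=O)OCC`: 3500 nM

Compound 1 gives the lowest of the three numbers in this assay, and its gap to either of the other two is beyond the usual scatter; compound 2 and compound 3 sit at the same number, so nothing separates them. Compound 2 differs from compound 1 at several places at once, so its value says nothing by itself about any single change.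

The next compound is compound 4, `COc1ccc(-c2[nH]c3ccc(OC)cc3c2/C=C(\C#N)S(=O)(=O)c2ccccc2)cc1`. It keeps the whole of compound 1 and differs from it only in one place: methoxy in place of hydrogen on an aromatic carbon. For the measured compounds named here, no measured pair isolates this change, so the expected step from compound 1 to compound 4 rests only on the position of compound 1 and on the general size of single substituent changes elsewhere in the set. A step of a 1.2-fold higher number from compound 1 to compound 4 (0.08 log units; within the scatter) is expected, small and not clearly beyond the scatter in either direction. Compound 4 is therefore estimated at 450 nM, with a range from 150 nM to 1400 nM.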

Compound 4, concentration for 50% growth inhibition: 654 nM
Compound 4: middle estimate off by 1.5-fold (0.16 log units), on the low side, and the stated range covers the measured number.
By their numbers in this assay, from the lowest: compounds 1 and 4 (each within the scatter of the next); then compounds 2 and 3 (each within the scatter of the next).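

In this assay, for the compounds shown here, methoxy in place of hydrogen on an aromatic carbon, meta to a fused ring and para to a fused ring, gives a 1.7-fold higher number from compound 1 to compound 4 (0.24 log units; within the scatter), the first pair that differs in one place. At this position of the shared core, methoxy therefore leaves compound 4 unseparated from compound 1, and the two cannot be ranked against each other. Nothing at hand explains the size of this step.

On these data alone, whether an amine, a carboxylic acid or a longer chain at this position would separate from compound 1 remains open. Also open is what the methoxy group already carried by compound 1 contributes, as no pair among these compounds isolates it.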